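This account rests on a few compounds, and the source may have more. Where it says the series, first, only, none or still open, it means among the compounds named here.

In an assay on Sf9 cells for inhibition of protein deacetylase HDAC6 (Homo sapiens), read by fluorescence, with a stated time of 40 min, tested at 100 nM (a lower number here means less inhibition, a higher number more inhibition at the concentration tested (going by the name of the read-out)), compound 1 `O=C(NO)c1ccc(NCc2nc(-c3cc4ccccc4s3)nn2-c2ccccc2)cc1` gives 65.5%, while compound 2 `CC(C)c1ccc(-c2nc(CNc3ccc(C(=O)NO)cc3)n(-c3ccccc3)n2)cc1` gives 27.6%. For the measured compounds named here, the one step measured so far is a number 37.9 percentage points lower from compound 1 to compound 2 (beyond the scatter), so compound 2 stands lowest of the two numbers, with compound 1 as its only neighbour.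

Compound 3 `Cc1ccsc1-c1nc(CNc2ccc(C(=O)NO)cc2)n(-c2ccccc2)n1` differs from compound 2 at the same aromatic carbon of the shared core: 3-methylthiophen-2-yl in place of 4-isopropylphenyl on an aromatic carbon. Going by the values given here, the only step that bears on this position is the large one seen in this assay from compound 1 to compound 2, where a group with a five-membered sulfur-containing aromatic ring gave the higher number. Compound 3 brings back a five-membered aromatic ring with one sulfur, though a smaller one, so compound 3 is expected to move partway back toward compound 1, with an expected step of a number 20.4 percentage points higher from compound 2 to compound 3 (beyond the scatter). Compound 3 is therefore estimated at 48%, within a range from 28% to 68%.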

Compound 3, a percentage reported as inhibition, at one concentration (the size of the read-out at that concentration, not a potency): 72.1%
Compound 3: middle estimate off by 24.1 percentage points, on the low side; measured number above the stated range.
By their numbers in this assay, from the lowest: compound 2; then compounds 1 and 3 (each within the scatter of the next).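

In this assay, 3-methylthiophen-2-yl in place of 4-isopropylphenyl gives a number 44.5 percentage points higher from compound 2 to compound 3 (beyond the scatter) at this aromatic carbon, a step as large as the earlier loss and opposite in direction. Going from 1-benzothiophen-2-yl to 3-methylthiophen-2-yl gives a number 6.6 percentage points higher from compound 1 to compound 3 (within the scatter) in the same assay, so the two groups bearing sulfur-containing five-membered aromatic rings cannot be told apart here, and among these three compounds only the 4-isopropylphenyl compound stands apart. Nothing given here explains the difference.

What the methyl group on the thiophene contributes stays open, as a plain thiophen-2-yl does not appear among the compounds shown. From the compounds shown here alone, it also remains open whether a pyridin-2-yl group, with nitrogen in a six-membered aromatic ring, would give a number like that of compound 2 or like those of compound 1 and compound 3.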